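Sulfamoyl in Place of Methoxy: Compound 4

The source may report more compounds than this note shows. Statements on the series, on what has been measured and on what is new or still open speak of the compounds shown alone.

Among the measured compounds shown here, compound 3 `COc1ccc(CNC(=O)c2ccc(C(C)(C)C)cc2)cc1` gives 150 nM in an assay on HeLa cells with Bile acid receptor (Homo sapiens) as the target, read by a luciferase reporter, with a stated time of 24 h (on this read-out lower numbers stand for an effect already at smaller amounts and higher numbers for an effect only at larger amounts of compound), the second highest of the three numbers known. Compound 1 `CC(C)(C)c1ccc(C(=O)NCc2ccc(NS(C)(=O)=O)cc2)cc1` gives 44 nM, and compound 2 `C[S+]([O-])c1ccc(CNC(=O)c2ccc(C(C)(C)C)cc2)cc1` gives 1300 nM. The steps between them were a 3.4-fold higher number from compound 1 to compound 3 (0.53 log units; beyond the scatter) and an 8.7-fold lower number from compound 2 to compound 3 (0.94 log units; beyond the scatter), both beyond the scatter, so the group on that aromatic carbon clearly matters. Compound 4 `CC(C)(C)c1ccc(C(=O)NCc2ccc(S(N)(=O)=O)cc2)cc1` carries sulfamoyl in place of methoxy on an aromatic carbon. Compound 1 and compound 2 both bear a sulfur-containing group in that place, and their steps to compound 3 run in opposite directions, so no direction can be called with confidence. An estimated 1.7-fold higher number from compound 3 to compound 4 (0.22 log units; within the scatter) is expected. Compound 4 is expected at 250 nM, within 50 nM to 1500 nM.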

Compound 4, half-maximal effective concentration: 1400 nM
Estimate against measurement, compound 4: 5.6-fold (0.75 log units) below, within the range that was stated.
By their numbers in this assay, from the lowest: compound 1; then compound 3; then compounds 2 and 4 (each within the scatter of the next).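

The step to sulfamoyl, a 9.3-fold higher number from compound 3 to compound 4 (0.97 log units; beyond the scatter), shows that a sulfur-bearing group at this place can lie well above methoxy, as the group of compound 2 does. Sulfamoyl and the group of compound 2 cannot be told apart here, with a 1.1-fold higher number from compound 2 to compound 4 (0.03 log units; within the scatter), while methanesulfonamido stands apart, with a 32-fold higher number from compound 1 to compound 4 (1.50 log units; beyond the scatter). Sulfur alone therefore does not set the number, and compound 1 goes against any rule that sulfur-bearing groups raise it. Nothing available explains these steps. Going by these compounds, whether a methylsulfonyl group or an amine here would fall with compound 1 or with compound 4 remains open.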